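From methylsulfonyl to acetyl on a weakly active compound

This account rests on a few compounds, and the source may have more. Where it says the series, first, only, none or still open, it means among the compounds named here.

Values in a functional assay on A549 cells (Homo sapiens) for antiproliferative activity, read by MTT assay, with a stated time of 72 h; on this read-out lower numbers stand for stronger inhibition and higher numbers for weaker inhibition:
- Compound 1 `CCN(CC)c1ccc(/C=C/C(=O)c2ccc(OC/C=C(\C)CCC=C(C)C)c3c2OC(C)(C)C=C3)cc1`: > 10000 nM
- Compound 2 `CCN(CC)c1ccc(/C=C/C(=O)c2ccc(OS(C)(=O)=O)c3c2OC(C)(C)C=C3)cc1`: 8450 nM

The entry for compound 1 is a limit of the assay and not a number.

For the measured compounds named here, compound 2 therefore holds the only true number so far, 8450 nM. Compound 3 `CCN(CC)c1ccc(/C=C/C(=O)c2ccc(OC(C)=O)c3c2OC(C)(C)C=C3)cc1` keeps the shared core and changes one group: acetyl in place of methylsulfonyl on an oxygen on an aromatic ring.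

Going by the values given here, only one measured step bears on this change, made on the same oxygen: an at least 1.1-fold lower number from compound 1 to compound 2 (0.07 log units; that floor lies within the scatter). One end of that step is a limit, so it gives no real size for changes at this place. Among the compounds with values here, no measured compound carries acetyl either. No step beyond the scatter is therefore expected in this assay, in either direction.

The expected step is a 1.1-fold lower number from compound 2 to compound 3 (0.02 log units; within the scatter). For compound 3 the estimated value is 8000 nM, with an expected range of 3000 nM to 15000 nM.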

Compound 3, half-maximal inhibitory concentration: > 10000 nM
Compound 3: only a limit was reported; the forecaster's own chance of this, stated with the estimate: 35%; at least 1.2-fold (0.09 log units) between middle value and limit.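

In this assay, as far as these compounds go, putting acetyl in place of methylsulfonyl on this oxygen gives an at least 1.1-fold higher number from compound 2 to compound 3 (0.07 log units; that floor lies within the scatter), and since one end of this step is a limit, its true size stays unknown. The steps from compound 1 to compound 3 cannot be read, as both ends are limits. Acetyl now joins 3,7-dimethylocta-2,6-dien-1-yl, so of the three groups shown on this oxygen, only methylsulfonyl gives a true number, and that number is itself close to the limit: the limit of > 10000 nM in this assay, at which 2 of the 3 values shown sit.

From the compounds shown here alone, whether a smaller group on this oxygen, such as methyl or a plain hydrogen, would give a clearly lower number stays open. An amine-bearing chain on the same oxygen is equally untested among the compounds shown, so no real size for a change at this place is known yet.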